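Cyanomethyl pyrazole series: methoxy-to-hydroxy step at low concentration

The source may hold more compounds than are shown below. What is called first, only, known or untested is meant among the compounds shown, and "the series" means these compounds.

Measured so far in a functional assay on PC-3 cells (Homo sapiens) for cytotoxicity, read by sulforhodamine B assay, with a stated time of 48 h, tested at 0.001 uM; on this read-out higher numbers stand for a weaker effect at the one concentration tested and lower numbers for a stronger effect:
compound 1, `COc1cc(C)cc(-c2c(-c3ccnc(-c4ccc(C(C)=O)cc4)c3)cnn2CC#N)c1`, 101%
compound 2, `Cc1cc(O)cc(-c2nn(CC#N)cc2-c2ccnc(-c3ccc(Oc4ccccc4)cc3)c2)c1`, 98%
compound 3, `COc1cc(C)cc(-c2nn(CC#N)cc2-c2ccnc(-c3ccc(N(C)C)cc3)c2)c1`, 97%

All three compounds leave the cells essentially untouched at the single concentration used. Compound 3 stands within the scatter of both compound 2 and compound 1; no difference among the three can be read from these numbers, and nothing here separates the three tail groups on the pyridine from one another.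

The next compound, compound 4, `Cc1cc(O)cc(-c2nn(CC#N)cc2-c2ccnc(-c3ccc(N(C)C)cc3)c2)c1`, is not yet measured. It differs from compound 3 in one place: hydrogen in place of methyl on an oxygen on an aromatic ring. The same exchange is already present in the pair of compound 2 against compound 1 and compound 3, where the hydroxy compound 2 gives 98%, indistinguishable from the methoxy compounds.

For the step in this assay, the expectation is therefore none beyond the scatter, with the estimated a number 1 percentage points higher from compound 3 to compound 4 (within the scatter) centred on no change. Compound 4 is estimated at 98% in this assay, with a range from 90% to 106%, i.e. again a value near full survival at this concentration.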

Compound 4, a percentage reported as activity, at one concentration (the size of the read-out at that concentration, not a potency): 105%
The estimate for compound 4 lay 7 percentage points below the measured number; the measured number falls inside the stated range.
By their numbers in this assay, from the lowest: compounds 3, 2, 1 and 4 (each within the scatter of the next).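

Working notes on the oxygen substituent: in this assay the methoxy-to-hydroxy change can now be read on a single matched pair with the dimethylamino tail held constant, and the step is a number 8 percentage points higher from compound 3 to compound 4 (within the scatter) and so gives no separation between the 3-methoxy-5-methylphenyl and 3-hydroxy-5-methylphenyl forms. The tail can also now be compared directly with the hydroxy group held constant, where dimethylamino in place of phenoxy on an aromatic carbon gives a number 7 percentage points higher from compound 2 to compound 4 (within the scatter) and likewise separates nothing at this single concentration. No further measurement bears on either step.

Because every step shown stays within the scatter, these compounds leave open whether either change would have any effect in this assay under conditions where the series reduces the read-out, as a single low concentration cannot show this. Also open, on these data alone, is whether anything other than methyl or hydrogen on that oxygen, such as a longer chain like ethyl, or an amine or a carboxylic acid in place of the hydroxy group on the aromatic ring, would move the read-out beyond the scatter.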